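Lengthening the branch beside the amine in compound 3

A few compounds are considered here, and "the series" means these few. Any claim that something is new, unique, unknown or untested is made for them only; others in the source may bear on it.

Measured so far:
compound 1, `OCCNCc1nc2c(OCC3CCCCC3)cccc2[nH]1` — 63.3%
compound 2, `OCCCCCNCc1nc2c(OCC3CCCCC3)cccc2[nH]1` — 23.7%
compound 3, `CCC(CO)NCc1nc2c(OCC3CCCCC3)cccc2[nH]1` — 94.3%

Three compounds share a core and differ only in the amine substituent. In an assay on cells for inhibition of interleukin-5 receptor subunit alpha (Mus musculus), read by WST assay, with a stated time of 48 h, tested at 30 uM, in the presence of a further agent that is not named here (a lower number here means less inhibition, a higher number more inhibition at the concentration tested (going by the name of the read-out)), compound 3 stands highest of the three, with compound 1 nearest and compound 2 furthest. The two measured steps that connect them are large: a number 39.6 percentage points lower from compound 1 to compound 2 (beyond the scatter), and a number 31 percentage points higher from compound 1 to compound 3 (beyond the scatter); the direct comparison gives a number 70.6 percentage points higher from compound 2 to compound 3 (beyond the scatter).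

The next compound, compound 4, `CCCC(CO)NCc1nc2c(OCC3CCCCC3)cccc2[nH]1`, follows from compound 3 by one change: methyl in place of hydrogen on a saturated chain carbon, three bonds along the chain from an amine nitrogen. Among the measured compounds shown here, the step that bears most on it is the one from compound 1 to compound 3, which added a carbon near the amine and raised inhibition strongly; the step from compound 1 to compound 2, which lengthened the hydroxy-bearing chain, went the other way. Compound 4 extends the branch by a single carbon, one bond further from the nitrogen, and compound 3 already lies near the top of the scale, so a step within the scatter, or a small one in either direction, is expected: a number 6.3 percentage points lower from compound 3 to compound 4 (within the scatter). For compound 4 in this assay a value of 88% is estimated, in the range 65% to 98%.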

Compound 4, a percentage reported as inhibition, at one concentration (the size of the read-out at that concentration, not a potency): 73.3%
For compound 4 the middle estimate is 14.7 percentage points above the measured one, and the stated range covers the measured number.
By their numbers in this assay, from the lowest: compound 2; then compounds 1 and 4 (each within the scatter of the next); then compound 3.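

In this assay the added methyl, on a saturated chain carbon three bonds along the chain from an amine nitrogen, gives a number 21 percentage points lower from compound 3 to compound 4 (beyond the scatter) and shows that the high reading of compound 3 does not carry over to a branch one carbon longer. The earlier compounds shown here showed only that ethyl in place of hydrogen on the carbon bound to the amine nitrogen raised the number, whereas propyl at that carbon gives a number 10 percentage points higher from compound 1 to compound 4 (within the scatter) and leaves compound 4 level with compound 1 within the scatter. The branched 1-(hydroxymethyl)butyl still reads clearly apart from the unbranched 5-hydroxypentyl, with a number 49.6 percentage points higher from compound 2 to compound 4 (beyond the scatter) and thus a margin that survives the longer branch.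

Nothing available here gives a measurement that would account for these steps. Going by these compounds, with only hydrogen, ethyl and propyl compared at this carbon, and each reading taken at a single concentration, it remains open how a methyl or isopropyl branch, a cyclopropyl ring, or a methoxy group in place of the hydroxy would read.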